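Hexylamino and branched-amino nucleoside sulfamates: compound 4

This account rests on a few compounds, and the source may have more. Where it says the series, first, only, none or still open, it means among the compounds named here.

Measured so far:
compound 1, `CCCCCCNc1ncnc2c1ncn2[C@@H]1O[C@H](COS(N)(=O)=O)[C@@H](O)[C@H]1O`, 160 nM
compound 2, `CCCCCCCNc1ncnc2c1ncn2[C@@H]1O[C@H](COS(N)(=O)=O)[C@@H](O)[C@H]1O`, 132 nM
compound 3, `CC(C)(C)CCNc1ncnc2c1ncn2[C@@H]1O[C@H](COS(N)(=O)=O)[C@@H](O)[C@H]1O`, 929 nM

Three compounds share one core and differ only in the chain on the ring nitrogen. In a functional assay on K562 cells (Homo sapiens) for antiproliferative activity, read by CellTiter-Glo, with a stated time of 72 h (on this read-out higher numbers stand for an effect only at larger amounts of compound and lower numbers for an effect already at smaller amounts), compound 1 gives 160 nM and compound 2 gives 132 nM; the step of a 1.2-fold lower number from compound 1 to compound 2 (0.08 log units; within the scatter) lies within the scatter. Compound 3 gives 929 nM, the highest number of the three, beyond the scatter from both: a 5.8-fold higher number from compound 1 to compound 3 (0.76 log units; beyond the scatter) and a 7.0-fold higher number from compound 2 to compound 3 (0.85 log units; beyond the scatter).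

Compound 4, `CC(C)(C)CC(C)(C)Nc1ncnc2c1ncn2[C@@H]1O[C@H](COS(N)(=O)=O)[C@@H](O)[C@H]1O`, carries 1,1,3,3-tetramethylbutyl in place of 3,3-dimethylbutyl on a nitrogen on an aromatic ring. Branching on the saturated chain carbon two bonds from the nitrogen already raised the number in the steps from compound 1 and compound 2 to compound 3; compound 4 adds further branching at the carbon bonded to the nitrogen itself, a change for which no direct step exists among the measured compounds. A further rise is therefore expected, of modest size: a 2.7-fold higher number from compound 3 to compound 4 (0.43 log units; beyond the scatter). For compound 4 the expected value in this assay is 2500 nM, with a range from 900 nM to 7000 nM.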

Compound 4, half-maximal effective concentration: > 1000 nM
Compound 4 ended at the assay's limit; the forecaster's own chance of this, stated with the estimate: 10%; the middle value does not contradict the limit.
By their numbers in this assay, from the lowest: compounds 2 and 1 (each within the scatter of the next); then compound 3. At a limit, above all of these: compound 4.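

In this assay compound 4 gives > 1000 nM, which is a limit of the assay and not a number. Even so, the straight chains stand clearly apart from it, with an at least 6.2-fold higher number from compound 1 to compound 4 (0.79 log units; beyond the scatter) and an at least 7.5-fold higher number from compound 2 to compound 4 (0.87 log units; beyond the scatter). Against 3,3-dimethylbutyl only a floor can be read, an at least 1.0-fold higher number from compound 3 to compound 4 (0.03 log units; that floor lies within the scatter), so the data do not separate 1,1,3,3-tetramethylbutyl from 3,3-dimethylbutyl on this nitrogen on an aromatic ring.

Open, going by these compounds, is the true size of the step from compound 3 to compound 4, which needs a number for compound 4 rather than a limit. Also open, on these data alone, is how a cyclohexyl group or a chain ending in a hydroxyl or an amine would read at this nitrogen in this assay.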